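Swapping a Thiophene Ring for a Single Iodine Atom

The source may report more compounds than this note shows. Statements on the series, on what has been measured and on what is new or still open speak of the compounds shown alone.

Of the compounds shown here, two sharing one core have been measured so far. Compound 1 `COc1ncnc2c1c(-c1ccoc1)cn2[C@@H]1O[C@H](CO)[C@@H](O)[C@H]1O` gives 130 nM in a functional assay on HCT-116 cells (Homo sapiens), read by MTT assay, with a stated time of 72 h (a lower number here means a stronger inhibitor, a higher number a weaker inhibitor), and compound 2 `COc1ncnc2c1c(-c1cccs1)cn2[C@@H]1O[C@H](CO)[C@@H](O)[C@H]1O` gives 440 nM. Within the data shown here, the one measured step, a 3.4-fold higher number from compound 1 to compound 2 (0.53 log units; beyond the scatter), leaves compound 2 with the highest of the two numbers, that is, the weaker of the pair.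

Compound 3 `COc1ncnc2c1c(I)cn2[C@@H]1O[C@H](CO)[C@@H](O)[C@H]1O` differs from compound 2 in one place: iodo in place of thiophen-2-yl on an aromatic carbon. Among the measured compounds shown here, the only step that can be compared, a 3.4-fold higher number from compound 1 to compound 2 (0.53 log units; beyond the scatter), exchanges one five-membered aromatic ring for another, whereas here a whole ring gives way to a single halogen atom, so that step offers little guidance on direction. A modest change in either direction is therefore expected, with wide uncertainty. For compound 3 the expected value is 500 nM, within a range of 100 nM to 2500 nM, which means an expected step of a 1.1-fold higher number from compound 2 to compound 3 (0.06 log units; within the scatter).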

Compound 3, half-maximal inhibitory concentration: > 20000 nM
Compound 3: a limit, no number; the forecaster's own chance of this, stated with the estimate: 5%; middle value at least 40-fold (1.60 log units) from the limit.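

Compound 3 yields only a limit of the assay, not a number: the limit of > 20000 nM in this assay, at which 1 of the 3 values shown sits. Even so, the change reads as an at least 45-fold higher number from compound 2 to compound 3 (1.65 log units; beyond the scatter), and against the furan-3-yl compound as an at least 150-fold higher number from compound 1 to compound 3 (2.18 log units; beyond the scatter), both far larger than the earlier exchange of one ring for another, a 3.4-fold higher number from compound 1 to compound 2 (0.53 log units; beyond the scatter). Among these three compounds, then, this aromatic carbon tolerates a swap between furan-3-yl and thiophen-2-yl with a modest loss, while replacing either ring with iodo costs far more, so the group at this position matters much more than the first pair could show.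

Going by these compounds, how far the true value of compound 3 lies past the limit stays unknown. Also open, on these data alone, is whether a phenyl ring, a small methyl group or an amine at this carbon would behave like the rings or like iodo.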